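The compounds below may be only part of what the source reports. "The series", "measured", "known", "first", "only" and "open" are said of these compounds alone.

Measured so far:
Compound 1 `O/N=C(\CCN1CCN(c2ccccn2)CC1)c1ccccc1` — 4.4 nM in a functional assay on HEK293 cells with D(4) dopamine receptor (Homo sapiens) as the target, read by FLIPR; a lower number here means that less compound is needed, a higher number that more compound is needed for the effect
Compound 2 `O/N=C(\CCN1CCN(c2ccccn2)CC1)c1ccc(F)cc1` — 31 nM in this assay

Compound 1 has the lowest of the two numbers. Among the measured compounds shown here, its nearest neighbour is compound 2, and the only single change measured here is a 7.0-fold higher number from compound 1 to compound 2 (0.85 log units; beyond the scatter). Compound 3 `Cc1cc(C)cc(/C(CCN2CCN(c3ccccn3)CC2)=N/O)c1` has not yet been measured. It differs from compound 1 at one place: 3,5-dimethylphenyl in place of phenyl on a carbon with a double bond to nitrogen. For the measured compounds named here, the one measured step touches the same ring, but it introduces a fluoro, not two methyl groups, so it bears on the new change only loosely. Still, the one alteration of this ring that has been tried pushed the number up by a modest amount beyond the scatter, and a somewhat similar outcome is expected for the present change. The estimated step is a 3.4-fold higher number from compound 1 to compound 3 (0.53 log units; beyond the scatter). For compound 3 the expected value is 15 nM, with a likely range from 4 nM to 60 nM.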

Compound 3, half-maximal effective concentration: 45.8 nM
Compound 3: the middle estimate sits 3.1-fold (0.48 log units) below what was measured; the range from low to high includes it.
By their numbers in this assay, from the lowest: compound 1; then compounds 2 and 3 (each within the scatter of the next).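

Placing two methyl groups on the phenyl ring of compound 1 gives a large step in this assay (a 10-fold higher number from compound 1 to compound 3 (1.02 log units; beyond the scatter)), so this ring tolerates this change no better than it tolerates the fluoro. Compound 2 and compound 3 cannot be told apart (a 1.5-fold higher number from compound 2 to compound 3 (0.17 log units; within the scatter)), even though their rings carry different groups, and the unsubstituted phenyl of compound 1 remains the ring with the lowest number. Nothing available here explains why either change raises the number.

The compounds shown leave open whether a ring carrying a single methyl, a chloro or a methoxy group would also raise the number. They also leave open whether any group on this ring can bring the number lower than that of compound 1.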